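A Second Aryl Swap on the Shared Core

This account rests on a few compounds, and the source may have more. Where it says the series, first, only, none or still open, it means among the compounds named here.

Compound 2 `C=CC(=O)Nc1cccc(NC(=O)CSc2nc(Nc3cccc(Br)c3)c3ccccc3n2)c1` gives 15000 nM in a functional assay on PC-3 cells (Homo sapiens) for inhibition, read by MTT assay, with a stated time of 72 h (on this read-out higher numbers stand for weaker inhibition and lower numbers for stronger inhibition), and it stands alongside compound 1 `C=CC(=O)Nc1cccc(NC(=O)CSc2nc(Nc3ccccc3Cl)c3ccccc3n2)c1`, which gives 14400 nM in this assay , a gap within the scatter. Compound 3 `C=CC(=O)Nc1cccc(NC(=O)CSc2nc(Nc3ccc(C(F)(F)F)cc3)c3ccccc3n2)c1` differs from compound 2 by 4-(trifluoromethyl)phenyl in place of 3-bromophenyl on a nitrogen on an aromatic ring. Among the compounds with values here, the only step seen so far changed the same aryl group on the same nitrogen, and because a 1.0-fold higher number from compound 1 to compound 2 (0.02 log units; within the scatter) stayed within the scatter, compound 3 is expected to show only no change at the digits printed from compound 2 to compound 3 (within the scatter) in this assay . Compound 3 is therefore estimated at 15000 nM, within a range from 5000 nM to 45000 nM.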

Compound 3, half-maximal inhibitory concentration: 12500 nM
Estimate against measurement, compound 3: 1.2-fold (0.08 log units) above; the range from low to high includes it.
By their numbers in this assay, from the lowest: compounds 3, 1 and 2 (each within the scatter of the next).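

In this assay, the 4-(trifluoromethyl)phenyl group on this nitrogen gives a 1.2-fold lower number from compound 2 to compound 3 (0.08 log units; within the scatter) and a 1.2-fold lower number from compound 1 to compound 3 (0.06 log units; within the scatter). With 2-chlorophenyl, 3-bromophenyl and 4-(trifluoromethyl)phenyl, this position now carries three different substituted phenyl groups, and all three compounds lie within the scatter of one another. Nothing available explains this flat result. The compounds shown leave open whether a phenyl group bearing an amine or a carboxylic acid would move the number beyond the scatter. They also leave open whether a longer alkyl chain in place of the phenyl ring would do so.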